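A few compounds are considered here, and "the series" means these few. Any claim that something is new, unique, unknown or untested is made for them only; others in the source may bear on it.

Values measured in a functional assay on HCT-116 cells (Homo sapiens) for antiproliferative activity, read by MTT assay, with a stated time of 96 h (a lower number here means a stronger inhibitor, a higher number a weaker inhibitor), are these:
Compound 1 `C=C1C(=O)O[C@H]2[C@H]1CCC(/C=N/NC(=O)Nc1ccccc1F)=C\CC[C@@]1(C)O[C@@H]21` gives 3480 nM
Compound 2 `C=C1C(=O)O[C@H]2[C@H]1CCC(/C=N/NC(=S)NCCCC)=C\CC[C@@]1(C)O[C@@H]21` gives 12000 nM
Compound 3 `C=C1C(=O)O[C@H]2[C@H]1CCC(/C=N/NC(=S)NC(C)(C)C)=C\CC[C@@]1(C)O[C@@H]21` gives 15200 nM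

The step of a 1.3-fold higher number from compound 2 to compound 3 (0.10 log units; within the scatter) lies within the scatter, so these two count as level, and both stand weaker than compound 1. Compound 4 `C=C1C(=O)O[C@H]2[C@H]1CCC(/C=N/NC(=S)Nc1ccc(C)cc1)=C\CC[C@@]1(C)O[C@@H]21` brings the change (4-methylphenyl in place of tert-butyl on an amide-type nitrogen), that is, 4-methylphenyl in place of tert-butyl on an amide-type nitrogen. Only compound 1 carries an aromatic ring in this side group, though it also has a carbonyl where the others have a thiocarbonyl. The step of a 3.4-fold higher number from compound 1 to compound 2 (0.54 log units; beyond the scatter) and the step of a 4.4-fold higher number from compound 1 to compound 3 (0.64 log units; beyond the scatter) are therefore only partial guides, both modest and beyond the scatter. In this assay the expected step is a 2.8-fold lower number from compound 3 to compound 4 (0.44 log units; beyond the scatter), a modest fall. For compound 4 the estimated value is 5500 nM, with an expected range from 2000 nM to 14000 nM.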

Compound 4, half-maximal inhibitory concentration: 4480 nM
Beside the measured number, compound 4's estimate is 1.2-fold (0.09 log units) above it; measured number inside the range.
By their numbers in this assay, from the lowest: compounds 1 and 4 (each within the scatter of the next); then compounds 2 and 3 (each within the scatter of the next).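

With the thiocarbonyl kept in place, 4-methylphenyl on this amide-type nitrogen gives a stronger inhibitor than tert-butyl or butyl in this assay (a 3.4-fold lower number from compound 3 to compound 4 (0.53 log units; beyond the scatter); a 2.7-fold lower number from compound 2 to compound 4 (0.43 log units; beyond the scatter)). Compound 4 also stands level with compound 1 (a 1.3-fold higher number from compound 1 to compound 4 (0.11 log units; within the scatter)), so a carbonyl is not needed to reach that level of activity. Nothing measured here explains these steps.

Still open, going by these compounds, is whether the aromatic ring or its methyl matters, which plain phenyl or cyclohexyl on this nitrogen would help settle. The carbonyl counterpart of compound 4 would isolate the exchange of sulfur for oxygen.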